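Swapping an aryl ether for a benzyl group on the quinoline core

The source may report more compounds than this note shows. Statements on the series, on what has been measured and on what is new or still open speak of the compounds shown alone.

Three compounds have so far been characterised in a physicochemical assay for acid dissociation. Compound 1 `COc1ccccc1Oc1ccc2c(NCCCNCc3ccco3)ccnc2c1` gives 9.28. Compound 2 `COc1ccc(Oc2ccc3c(NCCCNCc4cc(F)ccc4OC)ccnc3c2)cc1` gives 9.28 in this assay, which is level with compound 1 at the digits recorded. Compound 3 `CC(C)Cc1ccc2c(NCCCNCc3ccco3)ccnc2c1` gives 9.47 in this assay, and the difference between compound 2 and compound 3 is within the scatter of the method.

The only single-point step among these is a number 0.19 log units higher from compound 1 to compound 3 (within the scatter). That step is within the scatter, so replacing an aryl ether on the core with a plain carbon substituent did not measurably shift the acid dissociation constant.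

Compound 4 `COc1ccc(F)cc1CNCCCNc1ccnc2cc(Cc3cc(C)cc(C)c3)ccc12` is now to be measured in this assay. It differs from compound 2 in one place: 3,5-dimethylbenzyl in place of 4-methoxyphenoxy on an aromatic carbon. This change resembles the step from compound 1 to compound 3 in that an oxygen-linked aromatic group on the core is again replaced by a carbon-linked group, while the rest of the molecule, including the basic amine chain, is unchanged. On that basis the expected step is a number 0.12 log units higher from compound 2 to compound 4 (within the scatter), a shift that would fall within the scatter. The estimate for compound 4 in this assay is therefore 9.4, with a range from 9 to 9.8.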

Compound 4, acid dissociation constant: 9.47
Compound 4: middle estimate off by 0.07 log units, on the low side, within the range that was stated.
By their numbers in this assay, from the lowest: compounds 1, 2, 3 and 4 (each within the scatter of the next).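

In this assay, the swap on this aromatic carbon gives a number 0.19 log units higher from compound 2 to compound 4 (within the scatter), so the measurement does not separate the two compounds. Among these compounds, this pair adds something the earlier one could not show: 4-methoxyphenoxy and 3,5-dimethylbenzyl have the same count of heavy atoms and each holds one six-membered aromatic ring of carbon only, so the comparison keeps the size of the group and that ring while both oxygens and both hydrogen-bond acceptors of the group leave, and the step still lies within the scatter, now with a different group on the amine side chain from the one in compound 1 and compound 3. Nothing measured here offers an explanation for this result.

The compounds shown leave open whether the reading would also stay within the scatter with a group of another kind on this same aromatic carbon, such as an amine or a carboxylic acid. Both swaps shown put a carbon-linked group in place of an oxygen-linked one, so a longer chain or an amide at this place remains an open case.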